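The compounds below may be only part of what the source reports. "The series", "measured", "known", "first", "only" and "open" are said of these compounds alone.

Measured compounds:
Compound 1, `O=C(Nc1ccc(Cl)c(-c2nnc3c(Cl)cccn23)c1)c1ccc(C(F)(F)F)cc1Cl`: in a functional assay on MDA-MB-231 cells (Homo sapiens) for antiproliferative activity, read by MTT assay, with stated times of 72 h and 4 h (on this read-out higher numbers stand for weaker inhibition and lower numbers for stronger inhibition), compound 1 gives > 100000 nM, which is a limit of the assay.
Compound 2, `CS(=O)(=O)c1ccc(C(=O)Nc2ccc(Cl)c(-c3nnc4c(Cl)cccn34)c2)cc1`: compound 2 gives > 100000 nM, a limit.
Compound 3, `O=C(Nc1ccc(Cl)c(-c2nnc3c(Cl)cccn23)c1)c1ccc(Cl)cc1Cl`: compound 3 gives > 100000 nM, a limit.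

Compound 3 therefore stands only at a limit, as do the other two, see (the limit of > 100000 nM in this assay, at which 3 of the 3 values shown sit). The steps a step that the two limits leave unreadable from compound 1 to compound 3 and a step that the two limits leave unreadable from compound 2 to compound 3 cannot be read in size. Compound 4, `CS(=O)(=O)c1ccc(C(=O)Nc2ccc(Cl)c(-c3nnc4c(Cl)cccn34)c2)c(Cl)c1`, differs from compound 3 by methylsulfonyl in place of chloro on an aromatic carbon. Compound 2, which also carries a methylsulfonyl group, is likewise reported only as a limit. Going by the values given here, no measured step gives a readable direction for this change. Compound 4 is expected to sit at 100000 nM, range 30000 nM to 300000 nM, most likely again as a limit. The step of a number no higher from compound 3 to compound 4 (the limit leaves the size open) is expected to be none beyond the scatter.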

Compound 4, half-maximal inhibitory concentration: 37200 nM
Compound 4: the middle estimate sits 2.7-fold (0.43 log units) above what was measured; the measured number falls inside the stated range.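

In this assay, methylsulfonyl in place of chloro at this position, para to a large group, gives an at least 2.6-fold lower number from compound 3 to compound 4 (0.42 log units; beyond the scatter). Chloro in place of hydrogen gives an at least 2.6-fold lower number from compound 2 to compound 4 (0.42 log units; beyond the scatter), so methylsulfonyl without the chloro group does not give a readable value. Methylsulfonyl in place of trifluoromethyl gives an at least 2.6-fold lower number from compound 1 to compound 4 (0.42 log units; beyond the scatter), so this change also has a lower bound only.

From the compounds shown here alone, the steps among compound 1, compound 2 and compound 3 cannot be read, and the full size of each new step remains open: the limit of > 100000 nM in this assay, at which 3 of the 4 values shown sit. Whether an amine or a carboxylic acid at this position would lower the number further also remains open.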